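Ring swap on the amide-type nitrogen of the shared core

The source may report more compounds than this note shows. Statements on the series, on what has been measured and on what is new or still open speak of the compounds shown alone.

Measured so far:
compound 1 `CC(=O)NN(C(=O)NCc1ccccc1)c1ccccc1` — a functional assay on the whole organism with Mus musculus as the target, in the maximal electroshock model; on this read-out lower numbers stand for an effect already at smaller amounts and higher numbers for an effect only at larger amounts of compound: > 30 mg/kg
compound 2 `CC(=O)NN(C(=O)NCc1ccccc1)c1nccs1` — this assay: 6.2 mg/kg

Compound 1, with phenyl on the amide-type nitrogen, gives in this assay only a limit of the assay and no number (the limit of > 30 mg/kg in this assay, at which 1 of the 2 values shown sits). Compound 2, with 1,3-thiazol-2-yl in that place, is therefore the single real number shown in this assay; the other value is a limit, so compound 2 stands alone as the only point with a measured dose.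

For the measured compounds named here, the one measured step is an at least 4.8-fold lower number from compound 1 to compound 2 (0.68 log units; beyond the scatter).

Compound 3 `CC(=O)NN(C(=O)NCc1ccccc1)c1ncccn1` is not yet measured. The change is pyrimidin-2-yl in place of 1,3-thiazol-2-yl on an amide-type nitrogen. Going by the values given here, only the step from compound 1 to compound 2 bears on it, and that step concerned a phenyl replaced by a heteroaryl ring; here one two-heteroatom aromatic ring gives way to another, so no large shift in this assay is expected, and the expected step is a 1.6-fold higher number from compound 2 to compound 3 (0.21 log units; within the scatter). For compound 3 the estimated dose in this assay is 10 mg/kg, with a range from 3 mg/kg to 40 mg/kg.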

Compound 3, dose for half-maximal effect: about 30 mg/kg
Compound 3: the middle estimate sits 3.0-fold (0.48 log units) below what was measured; low and high end bracket the measured number.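

In this assay, pyrimidin-2-yl in place of 1,3-thiazol-2-yl on the amide-type nitrogen gives a 4.8-fold higher number from compound 2 to compound 3 (0.68 log units; beyond the scatter). This position therefore separates one heteroaryl ring from another, which the step away from phenyl could not show: the two rings have the same counts of hetero atoms, hydrogen-bond donors and hydrogen-bond acceptors, and neither carries a net charge, yet the step lies beyond the scatter. Compound 1 remains a limit of the assay. Pyrimidin-2-yl in place of phenyl on the amide-type nitrogen gives a number no higher from compound 1 to compound 3 (the limit leaves the size open), and the size of that step cannot be read: the limit of > 30 mg/kg in this assay, at which 1 of the 3 values shown sits.

The change from compound 2 to compound 3 alters ring size and swaps sulfur for nitrogen at once, so these compounds cannot say which of the two matters; 1,3-oxazol-2-yl and pyridin-2-yl at the same place would begin to pull them apart. Also open, from the compounds shown here alone, is how far 1,3-thiazol-2-yl tolerates substitution, for example a methyl group or an amine on the ring, and whether any such ring keeps the number of compound 2 in this assay.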